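Series notes: benzyl to (benzyloxy)methoxy on the fused core

The compounds below may be only part of what the source reports. "The series", "measured", "known", "first", "only" and "open" are said of these compounds alone.

Measured compounds
- compound 1 `Cc1ccc(C(O)c2c(-c3ccccc3)c(-c3ccccc3)n3ccc(C#N)cc23)cc1`: "not determined" (no result reported)
- compound 2 `COc1cccc(C(=O)Oc2c(-c3ccccc3)c(-c3ccccc3)n3ccc(C#N)cc23)c1`: "not determined" (no result reported)
- compound 3 `N#Cc1ccn2c(-c3ccccc3)c(-c3ccccc3)c(Cc3ccccc3)c2c1`: 46000 nM

Three compounds of this series carry a shared fused core with two phenyl groups and a nitrile. In an assay for inhibition of Polyunsaturated fatty acid lipoxygenase ALOX15 (Oryctolagus cuniculus) (a higher number here means a weaker inhibitor, a lower number a stronger inhibitor), compound 1 gives "not determined" (no result reported) and compound 2 gives "not determined" (no result reported), so for neither of them is a number available. In this assay, within the data shown here, compound 3 gives 46000 nM, the only number in the set, and it marks compound 3 as a weak inhibitor with nothing to rank it against.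

Compound 4 `N#Cc1ccn2c(-c3ccccc3)c(-c3ccccc3)c(OCOCc3ccccc3)c2c1` is not yet measured. The difference from compound 3 is counted as follows: (benzyloxy)methoxy in place of benzyl on an aromatic carbon. The change exchanges the benzyl for a (benzyloxy)methoxy group on an aromatic carbon of the five-membered aromatic ring with one nitrogen, and adds two hydrogen-bond acceptors.

Among the measured compounds shown here, no measured pair in the set shows how such a change plays out, so the expectation rests on compound 3 alone. The step from compound 3 to compound 4 is expected to be small, a 1.2-fold higher number from compound 3 to compound 4 (0.08 log units; within the scatter), leaning if anything toward a weaker inhibitor but not beyond the usual scatter. Compound 4 is accordingly estimated at 55000 nM in this assay, with a range from 15000 nM to 200000 nM.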

Compound 4, half-maximal inhibitory concentration: 39000 nM
Compound 4: the middle estimate sits 1.4-fold (0.15 log units) above what was measured; the range from low to high includes it.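

In this assay the exchange of benzyl for (benzyloxy)methoxy on an aromatic carbon of the five-membered aromatic ring comes with a 1.2-fold lower number from compound 3 to compound 4 (0.07 log units; within the scatter), so compound 3 and compound 4 cannot be told apart. This single pair shows that, at this position, the number does not respond to a group that brings two oxygens and two hydrogen-bond acceptors while keeping a six-membered aromatic ring of carbon only, and compound 4 at 39000 nM remains a weak inhibitor, as compound 3 was. No independent data bear on why the two compounds read alike, so the pair records an outcome without an explanation.

One pair cannot say whether an amine, a carboxylic acid or a shorter alkoxy chain in this place would move the number beyond the scatter, or whether the terminal phenyl ring that both groups carry is needed at all. The nitrile and the two phenyl groups are common to all the compounds shown, so what replacing them, for example the nitrile with a primary amide, would do to the number also stays open.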